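This account rests on a few compounds, and the source may have more. Where it says the series, first, only, none or still open, it means among the compounds named here.

Measured so far in an assay on HEK293 cells for agonist activity at transient receptor potential cation channel subfamily M member 8 (Homo sapiens), read by fluorescence and calcium flux, with a stated time of 15 min; a higher number here means that more compound is needed for the effect, a lower number that less compound is needed:
Compound 1 `CCN(Cc1cccnc1)C(=O)COc1ccc(C)cc1` gives 15400 nM.
Compound 2 `CCN(Cc1ccsc1)C(=O)COc1ccc(C)cc1` gives 88 nM.

Among the measured compounds shown here, compound 2 has the lowest of the two numbers; the one measured step, a 180-fold lower number from compound 1 to compound 2 (2.24 log units; beyond the scatter), is large. The next compound, compound 3 `CCN(Cc1ccccc1)C(=O)COc1ccc(C)cc1`, is not yet measured. It differs from compound 2 in one place: phenyl in place of thiophen-3-yl on a saturated chain carbon bound to an amide-type nitrogen. For the measured compounds named here, no measured step swaps thiophen-3-yl for phenyl; the single step that bears on this position compares pyridin-3-yl instead, so it only shows that the ring on that chain carbon can matter greatly. Given that, a small step at most is expected, a 1.3-fold higher number from compound 2 to compound 3 (0.10 log units; within the scatter), possibly none beyond the scatter. Compound 3 is estimated at 110 nM, range 30 nM to 400 nM.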

Compound 3, half-maximal effective concentration: 1880 nM
For compound 3 the middle estimate is 17-fold (1.23 log units) below the measured one; measured number outside the range, above it.
By their numbers in this assay, from the lowest: compound 2; then compound 3; then compound 1.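

In this assay, the ring on this chain carbon is not a freely exchangeable part: phenyl in place of thiophen-3-yl gives a 21-fold higher number from compound 2 to compound 3 (1.33 log units; beyond the scatter), so compound 2's low number depends on the thiophen-3-yl ring. Phenyl in place of pyridin-3-yl gives an 8.2-fold lower number from compound 1 to compound 3 (0.91 log units; beyond the scatter), so even two six-membered aromatic rings are told apart at this position. Nothing measured here explains these differences. On these data alone, a furan-3-yl or thiophen-2-yl ring at this place remains open, as does whether the order of the three rings would hold on a different core.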